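Carboxy in Place of Methylsulfonyl on the Sulfonyl-Linked Ring

The source may hold more compounds than are shown below. What is called first, only, known or untested is meant among the compounds shown, and "the series" means these compounds.

Compound 1 `COc1cc2nc(N3CCN(S(=O)(=O)c4ccccc4[N+](=O)[O-])CC3)nc(N)c2cc1OC`: 35000 nM in a functional assay on PC-3 cells (Homo sapiens) for inhibition; on this read-out higher numbers stand for weaker inhibition and lower numbers for stronger inhibition
Compound 2 `COc1cc2nc(N3CCN(S(=O)(=O)c4ccc(S(C)(=O)=O)cc4)CC3)nc(N)c2cc1OC`: 17000 nM

Within the data shown here, compound 2 gives the lowest of the two numbers in this assay; the single measured step in the set, a 2.1-fold lower number from compound 1 to compound 2 (0.31 log units; beyond the scatter), lies beyond the scatter. Compound 3 `COc1cc2nc(N3CCN(S(=O)(=O)c4ccc(C(=O)O)cc4)CC3)nc(N)c2cc1OC` differs from compound 2 by carboxy in place of methylsulfonyl on an aromatic carbon. Among the measured compounds shown here, only that one step bears on this change, and it was modest, exchanging one substituted aryl group for another; no measured pair carries a carboxy group. The expected step is therefore a 1.2-fold higher number from compound 2 to compound 3 (0.07 log units; within the scatter), within the scatter. Compound 3 is estimated at 20000 nM, with a range from 7000 nM to 60000 nM.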

Compound 3, half-maximal inhibitory concentration: 53000 nM
The estimate for compound 3 lay 2.7-fold (0.42 log units) below the measured number; measured number inside the range.
By their numbers in this assay, from the lowest: compound 2; then compounds 1 and 3 (each within the scatter of the next).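

In this assay, carboxy in place of methylsulfonyl on this aromatic carbon, para to a large group, gave a 3.1-fold higher number from compound 2 to compound 3 (0.49 log units; beyond the scatter), so the read-out responds to the group at this place. Against the 2-nitrophenyl of compound 1, the 4-carboxyphenyl group gave a 1.5-fold higher number from compound 1 to compound 3 (0.18 log units; within the scatter), so compound 3 does not keep the edge that compound 2 holds over compound 1. Nothing at hand tells why the number moved. As far as these compounds go, whether an amide, a methyl ester or an amine here would stand with compound 2 or with compound 3 remains open.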